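The compounds below may be only part of what the source reports. "The series", "measured", "known", "first", "only" and "open" are said of these compounds alone.

This account follows the step from compound 1 to compound 3. Compound 1 `C=CCN(C)c1nc(N)nc2c1ncn2[C@H]1C[C@H](N=[N+]=[N-])[C@@H](CO)O1` was tested in an ADME assay on CCRF-CEM cells (Homo sapiens) for cytotoxicity, with a stated time of 5 days (on this read-out lower numbers stand for stronger inhibition and higher numbers for weaker inhibition), where compound 1 gives 27000 nM. A second compound, compound 2 `COc1nc(NC2CC2)c2ncn([C@H]3C[C@H](N=[N+]=[N-])[C@@H](CO)O3)c2n1`, went through this assay as well; for compound 2 this assay reports only a limit, > 100000 nM, and no number. Compound 1 therefore stands as the holder of the only number shown in this assay, the other reading being a limit (the limit of > 100000 nM in this assay, at which 1 of the 2 values shown sits). Compound 3 `CN(C)c1nc(N)nc2c1ncn2[C@H]1C[C@H](N=[N+]=[N-])[C@@H](CO)O1` has not yet been measured in this assay. It differs from compound 1 by a single change: hydrogen in place of vinyl on a saturated chain carbon bound to a nitrogen on an aromatic ring. No step between two measured compounds has been shown, so the size of the step from compound 1 to compound 3 has to be judged from the change alone. A small step is expected in this assay, toward weaker inhibition if any, and it may well sit within the usual scatter of this assay. On that basis compound 3 is expected to give about 40000 nM in this assay, within a range from 12000 nM to 100000 nM. The expected step is a 1.5-fold higher number from compound 1 to compound 3 (0.17 log units; within the scatter), a modest one.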

Compound 3, half-maximal inhibitory concentration: > 100000 nM
Compound 3 ended at the assay's limit; the forecaster's own chance of this, stated with the estimate: 30%; middle value at least 2.5-fold (0.39 log units) from the limit.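

In this assay, for the compounds shown here, the change from allyl(methyl)amino to dimethylamino gives the first step that can be read at this position: an at least 3.7-fold higher number from compound 1 to compound 3 (0.56 log units; beyond the scatter). The step lies beyond the scatter, so in this series the vinyl end of the allyl chain is not a neutral part of the structure, and of this pair only compound 1 keeps a measured number. Compound 3 carries a limit and not a number, so the step is a lower bound and its full size cannot be read: the limit of > 100000 nM in this assay, at which 2 of the 3 values shown sit.

The compounds shown leave open whether the step follows the double bond or the length of the chain, and a propyl group in place of allyl would separate the two. On these data alone, how a longer chain such as butyl, a ring-bearing group such as benzyl, or an oxygen-bearing chain such as 2-hydroxyethyl would read at the same place in this assay also remains open, and so does whether any of them would move the number further toward stronger inhibition than compound 1 shows.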